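From Piperidin-1-yl to (Cyclopropylmethyl)amino on the Carbonyl

The source may report more compounds than this note shows. Statements on the series, on what has been measured and on what is new or still open speak of the compounds shown alone.

Compound 1 `O=C1C=CC(=O)C(c2cc(-c3ccc(C(=O)N4CCCCC4)s3)on2)=C1` and compound 2 `COc1ccc(OC)c(-c2cc(-c3ccc(C(=O)N4CCCCC4)s3)on2)c1` share a core and were both tested in a functional assay on A549 cells (Homo sapiens) for cytotoxicity, read by XTT assay, with a stated time of 72 h; on this read-out higher numbers stand for weaker inhibition and lower numbers for stronger inhibition. Compound 1 reaches only the limit of the assay, > 30000 nM. Compound 2 likewise yields only a limit, > 30000 nM, so no number places it on the scale. Both values sit at the limit of > 30000 nM in this assay, at which 2 of the 2 values shown sit. Compound 3 `COc1ccc(OC)c(-c2cc(-c3ccc(C(=O)NCC4CC4)s3)on2)c1` differs from compound 2 by (cyclopropylmethyl)amino in place of piperidin-1-yl on a carbonyl carbon. Going by the values given here, no measured step shows what this change does here, so no direction can be read from the data. Compound 3 is therefore expected to give 30000 nM, within 10000 nM to 100000 nM, most likely again as a limit. The step of a number no higher from compound 2 to compound 3 (the limit leaves the size open) is estimated as none beyond the scatter.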

Compound 3, half-maximal inhibitory concentration: > 30000 nM
Compound 3: a limit, no number; the forecaster's own chance of this, stated with the estimate: 70%; the middle value sits exactly at the limit.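

Compound 2 and compound 3 both stand only as limits, so no step can be read from the change of piperidin-1-yl to (cyclopropylmethyl)amino. The compounds shown leave open whether this change alters cytotoxicity at all.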